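Cyclopropyl for methyl on a difluorophenyl amide core

The compounds below may be only part of what the source reports. "The series", "measured", "known", "first", "only" and "open" are said of these compounds alone.

Of the compounds shown here, three share a scaffold and have been measured in a functional assay on K562 cells (Homo sapiens) for inhibition, read by MTT assay, with a stated time of 48 h; on this read-out higher numbers stand for weaker inhibition and lower numbers for stronger inhibition. Compound 1 `CC(=O)Nc1nc2ccc(-c3cn([C@@H]4CN[C@H](C(=O)Nc5ccc(Br)cc5)C4)nn3)nc2s1` gives 5020 nM in this assay. Compound 2 `O=C(Nc1nc2ccc(-c3cn([C@@H]4CN[C@H](C(=O)Nc5ccc(Br)cc5)C4)nn3)nc2s1)C1CC1` gives 8160 nM, and a 1.6-fold higher number from compound 1 to compound 2 (0.21 log units; within the scatter); the change is cyclopropyl in place of methyl on a carbonyl carbon. Compound 3 `CC(=O)Nc1nc2ccc(-c3cn([C@@H]4CN[C@H](C(=O)Nc5ccc(F)c(F)c5)C4)nn3)nc2s1` gives 63000 nM, and a 13-fold higher number from compound 1 to compound 3 (1.10 log units; beyond the scatter); the change there is 3,4-difluorophenyl in place of 4-bromophenyl on an amide-type nitrogen. Compound 4 `O=C(Nc1nc2ccc(-c3cn([C@@H]4CN[C@H](C(=O)Nc5ccc(F)c(F)c5)C4)nn3)nc2s1)C1CC1` has not yet been measured. It differs from compound 3 by cyclopropyl in place of methyl on a carbonyl carbon, the same change as from compound 1 to compound 2, at the same place. Because a 1.6-fold higher number from compound 1 to compound 2 (0.21 log units; within the scatter) stayed within the scatter, compound 4 is expected to sit close to compound 3, with a 1.5-fold higher number from compound 3 to compound 4 (0.18 log units; within the scatter) expected. The estimate for compound 4 is 95000 nM, expected to lie between 40000 nM and 250000 nM.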

Compound 4, half-maximal inhibitory concentration: 40700 nM
The estimate for compound 4 lay 2.3-fold (0.37 log units) above the measured number, and the stated range covers the measured number.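

In this assay, cyclopropyl in place of methyl on a carbonyl carbon gives a 1.5-fold lower number from compound 3 to compound 4 (0.19 log units; within the scatter), and this step and its counterpart on the 4-bromophenyl core both stay within the scatter and do not differ from each other: the same change on two cores in this assay, a 1.6-fold higher number (0.21 log units; within the scatter) from compound 1 to compound 2 and a 1.5-fold lower number (0.19 log units; within the scatter) from compound 3 to compound 4, 2.5-fold (0.40 log units) apart, within the scatter of two such steps. The change from 4-bromophenyl to 3,4-difluorophenyl, with cyclopropyl already in place, gives a 5.0-fold higher number from compound 2 to compound 4 (0.70 log units; beyond the scatter), and this too agrees with its counterpart: the same change on two cores in this assay, a 13-fold higher number (1.10 log units; beyond the scatter) from compound 1 to compound 3 and a 5.0-fold higher number (0.70 log units; beyond the scatter) from compound 2 to compound 4, 2.5-fold (0.40 log units) apart, within the scatter of two such steps. Across these four compounds, each change therefore carries over to the other core, but two cores per change cannot show that this holds more widely in the series. From the compounds shown here alone, it remains open whether a longer chain, such as propyl, or an amine in place of cyclopropyl would also leave the number unchanged. The same question applies to a chlorophenyl or methoxyphenyl group on the amide nitrogen.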